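The compounds below may be only part of what the source reports. "The series", "measured", "known", "first", "only" and "open" are said of these compounds alone.

Values in a functional assay on A549 cells (Homo sapiens) for antiproliferative activity, read by MTT assay, with a stated time of 24 h; on this read-out higher numbers stand for weaker inhibition and lower numbers for stronger inhibition:
- Compound 1 `Cc1ccccc1NNC(=O)c1ccccc1NS(=O)(=O)c1cnc(O)nc1O`: > 20000 nM, a limit of the assay
- Compound 2 `O=C(NNc1ccccc1F)c1ccccc1NS(=O)(=O)c1cnc(O)nc1O`: 9610 nM
- Compound 3 `O=C(NNc1ccc(F)cc1)c1ccccc1NS(=O)(=O)c1cnc(O)nc1O`: > 20000 nM, a limit of the assay
- Compound 4 `Cc1ccccc1C(=O)NNC(=O)c1ccccc1NS(=O)(=O)c1cnc(O)nc1O`: not yet measured

Compound 3 stands at > 20000 nM, which is a limit and not a number. The series as a whole shows (the limit of > 20000 nM in this assay, at which 2 of the 3 values shown sit). Only compound 2 gives a number, 9610 nM.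

The change to compound 4 is a new kind of substituent: (2-methylphenyl)carbonyl in place of 4-fluorophenyl on an amine nitrogen. Thus (2-methylphenyl)carbonyl comes in place of 4-fluorophenyl on an amine nitrogen. For the measured compounds named here, no measured step makes this exchange. The nearest evidence is an at least 2.0-fold higher number from compound 2 to compound 3 (0.31 log units; beyond the scatter) and an at least 2.0-fold lower number from compound 1 to compound 2 (0.31 log units; beyond the scatter), both changes at the same amine nitrogen and both beyond the scatter, while a step that the two limits leave unreadable from compound 1 to compound 3 has no readable size. These steps give no direction for the new group, so no step beyond the scatter is expected in this assay, and a further limit is the likeliest result. The expected step is a number no higher from compound 3 to compound 4 (the limit leaves the size open). Compound 4 is estimated at 20000 nM, with an expected range from 9000 nM to 45000 nM.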

Compound 4, half-maximal inhibitory concentration: 5450 nM
Compound 4: the middle estimate sits 3.7-fold (0.56 log units) above what was measured; the measured number lies below the stated range.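

In this assay, (2-methylphenyl)carbonyl on this amine nitrogen gives an at least 3.6-fold lower number from compound 3 to compound 4 (0.56 log units; beyond the scatter) and an at least 3.6-fold lower number from compound 1 to compound 4 (0.56 log units; beyond the scatter), so this position is not limited to the phenyl groups seen earlier. Against the best-defined earlier compound, the same exchange gives a 1.8-fold lower number from compound 2 to compound 4 (0.25 log units; within the scatter), which leaves compound 4 and compound 2 indistinguishable in this assay. For the compounds shown here, the 2-fluorophenyl group is therefore no longer the only group on this nitrogen to give a number rather than a limit, and a carbonyl-bearing group serves there as well.

As far as these compounds go, the two steps from limits fix only a minimum size, and their full size stays open: the limit of > 20000 nM in this assay, at which 2 of the 4 values shown sit. Also open, from the compounds shown here alone, is whether the carbonyl or its 2-methylphenyl part carries the change, and how a plain acetyl or a benzenesulfonyl group would read at this nitrogen.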